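Nitro scan on the phenyl thiosemicarbazone series: compound 4

This account rests on a few compounds, and the source may have more. Where it says the series, first, only, none or still open, it means among the compounds named here.

Values in a functional assay on T98G cells (Homo sapiens) for cytotoxicity, read by MTT assay, with a stated time of 48 h; a higher number here means a weaker inhibitor, a lower number a stronger inhibitor:
- compound 1 `C/C(=N/NC(=S)Nc1ccccc1)c1ccccn1`: 6.81 nM
- compound 2 `C/C(=N/NC(=S)Nc1cccc([N+](=O)[O-])c1)c1ccccn1`: 140 nM
- compound 3 `C/C(=N\NC(=S)Nc1ccccc1)c1ccccn1`: 6.81 nM

Compound 1 shares the lowest of the three numbers with compound 3 and lies well under compound 2. The step of no change at the digits printed from compound 1 to compound 3 (within the scatter) goes with the fact that compounds 1 and 3 differ only in the configuration as drawn, and it says nothing about a new substituent.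

Compound 4 `C/C(=N/NC(=S)Nc1ccccc1[N+](=O)[O-])c1ccccn1` keeps the core of compound 1 and takes nitro in place of hydrogen on an aromatic carbon, ortho to a large group: nitro in place of hydrogen on an aromatic carbon.

Within the data shown here, the one measured step that bears on this is a 21-fold higher number from compound 1 to compound 2 (1.31 log units; beyond the scatter), a large step for the same exchange on a different aromatic carbon. With only that single case, the size cannot be carried over directly. A higher number in this assay is expected, beyond the scatter, and probably of similar or somewhat smaller size.

The estimated step is an 8.8-fold higher number from compound 1 to compound 4 (0.95 log units; beyond the scatter).

For compound 4 the expected value is 60 nM, with an estimated range of 10 nM to 350 nM.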

Compound 4, half-maximal inhibitory concentration: 6.61 nM
Beside the measured number, compound 4's estimate is 9.1-fold (0.96 log units) above it, outside the stated range (below it).
By their numbers in this assay, from the lowest: compounds 4, 1 and 3 (each within the scatter of the next); then compound 2.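

In this assay the step of a 1.0-fold lower number from compound 1 to compound 4 (0.01 log units; within the scatter) shows that nitro in place of hydrogen on an aromatic carbon, ortho to a large group, is accommodated at this position with no change beyond the scatter. The earlier compounds shown here showed this exchange only on a different aromatic carbon, the single case being a 21-fold higher number from compound 1 to compound 2 (1.31 log units; beyond the scatter), so the large step seen there does not follow from the presence of nitro alone and depends on where the group sits within this set. Nothing in the information at hand accounts for this dependence on place.

Going by these compounds, whether an amine or a carboxylic acid at this same position would also stay within the scatter of compound 1 remains open. Also open, on these data alone, is how nitro behaves on the remaining aromatic carbons of that ring.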